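The compounds below may be only part of what the source reports. "The series", "measured", "known", "first", "only" and "open" are said of these compounds alone.

Measured so far in an assay on Sf9 cells for inhibition of mitogen-activated protein kinase kinase kinase 14 (Homo sapiens), read by ADP-Glo, with a stated time of 60 min; a lower number here means a stronger inhibitor, a higher number a weaker inhibitor:
- compound 1 `Cc1nn(C(=O)C2CCC2)c(N)c1-c1ccc(Cl)c(Cl)c1`: 2900 nM
- compound 2 `Cc1nn(C(=O)c2cccnc2)c(N)c1-c1ccc(Cl)c(Cl)c1`: > 100000 nM
- compound 3 `Cc1c(-c2ccc(Cl)c(Cl)c2)c(N)nn1C(=O)C1CCC1`: > 100000 nM

Among the compounds with values here, compound 1 is the only member of the set with a numerical reading; in this assay compound 1 gives 2900 nM. For compound 2 the reading is a limit of the assay, not a number: compound 2 gives > 100000 nM. The change between them is pyridin-3-yl in place of cyclobutyl on a carbonyl carbon, and the step is an at least 34-fold higher number from compound 1 to compound 2 (1.53 log units; beyond the scatter). For compound 3 the reading is likewise a limit: compound 3 gives > 100000 nM. Compound 3 and compound 1 contain the same atoms joined differently; the difference between the two cores is not broken down here.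

Compound 4 `Cc1c(-c2ccc(Cl)c(Cl)c2)c(N)nn1C(=O)c1cccnc1` is not yet measured. It differs from compound 3 by pyridin-3-yl in place of cyclobutyl on a carbonyl carbon, the same change already seen from compound 1 to compound 2, at a place described in identical words. Since compound 3 already sits at the limit of > 100000 nM in this assay, at which 2 of the 3 values shown sit, and the earlier instance of this change moved the reading toward that limit, compound 4 is expected to remain at the limit as well, with an expected step that the limit leaves unreadable from compound 3 to compound 4. The estimate for compound 4 in this assay is 200000 nM, expected between 50000 nM and 1000000 nM.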

Compound 4, half-maximal inhibitory concentration: > 100000 nM
Compound 4: no number, only a limit; the forecaster's own chance of this, stated with the estimate: 85%; the middle value does not contradict the limit.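

In this assay compound 4 gives > 100000 nM, a limit and not a number. Within the data shown here, compound 3 also gives only a limit, so no step between compound 3 and compound 4 can be read. The reading of the series now stands as follows: the limit of > 100000 nM in this assay, at which 3 of the 4 values shown sit. The compounds shown leave open how far the core of compound 3 and its pyridin-3-yl counterpart, compound 4, lie from each other.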